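Amide variations on a shared alkyne-linked kinase inhibitor core

The source may report more compounds than this note shows. Statements on the series, on what has been measured and on what is new or still open speak of the compounds shown alone.

Measured so far in an assay on isolated protein for inhibition of MAP kinase-interacting serine/threonine-protein kinase 1 (Homo sapiens), read by HTRF, in the presence of a further agent that is not named here; on this read-out lower numbers stand for stronger inhibition and higher numbers for weaker inhibition:
Compound 1, `CNC(=O)c1cccc(C#Cc2ccccc2Nc2ncnc3ccc(Cl)nc23)c1`, gives > 10000 nM in this assay.
Compound 2, `COC(=O)c1cccc(C#Cc2ccccc2Nc2ncnc3ccc(Cl)nc23)c1`, gives > 10000 nM in this assay.

Both of these values are limits of the assay rather than numbers. The value of compound 1 is a limit. The value of compound 2 is likewise a limit, so compound 2 stands at the edge of what this assay can report, and the step that the two limits leave unreadable from compound 1 to compound 2 cannot be sized; this is because of the limit of > 10000 nM in this assay, at which 2 of the 2 values shown sit.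

Compound 3, `CN(C)C(=O)c1cccc(C#Cc2ccccc2Nc2ncnc3ccc(Cl)nc23)c1`, differs from compound 2 by dimethylamino in place of methoxy on a carbonyl carbon. Among the measured compounds shown here, the only measured step on this shared core, from the methylamino compound to the methoxy compound, is unreadable, so there is no measured step that speaks for or against a shift in this assay. With both known neighbours at the limit, compound 3 is expected to stay at or near that limit, and the step that the limit leaves unreadable from compound 2 to compound 3 is estimated to be none beyond the scatter. Compound 3 is therefore expected to give about 15000 nM in this assay, in a range from 7000 nM to 40000 nM.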

Compound 3, half-maximal inhibitory concentration: > 10000 nM
Compound 3: no number, only a limit; the forecaster's own chance of this, stated with the estimate: 85%; the middle value is on the limit's open side.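

Among the compounds shown here, no step among compound 1, compound 2 and compound 3 can be read, because all three sit at a limit of the assay rather than at a number: the limit of > 10000 nM in this assay, at which 3 of the 3 values shown sit. What the compounds shown leave open is how strongly each inhibits the kinase, and whether changing the group on the carbonyl carbon alters that inhibition at all.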